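Chloro Replaced by Methyl on Compound 2

The source may report more compounds than this note shows. Statements on the series, on what has been measured and on what is new or still open speak of the compounds shown alone.

Of the compounds shown here, two have been measured in a functional assay on HEK293 cells for agonist activity at Neuronal acetylcholine receptor; alpha4/beta2 (Homo sapiens), read by FLIPR; a higher number here means that more compound is needed for the effect, a lower number that less compound is needed. Compound 1 `Clc1cc(N2C[C@@H]3CCNC[C@@H]32)cnc1Cl` gives 271 nM, and its mirror image, compound 2 `Clc1cc(N2C[C@H]3CCNC[C@H]32)cnc1Cl`, gives 176 nM. The step of a 1.5-fold lower number from compound 1 to compound 2 (0.19 log units; within the scatter) rests on (the fact that compounds 1 and 2 differ only in the configuration as drawn). Within the data shown here, compound 2 thus holds the lowest of the two numbers, with compound 1 its only neighbour, and the two sit within the scatter of each other, so neither can be called the more active.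

Compound 3 `Cc1cc(N2C[C@H]3CCNC[C@H]32)cnc1Cl` is the next compound to be measured. It differs from compound 2 by methyl in place of chloro on an aromatic carbon, while the configuration of compound 2 is kept. Among the measured compounds shown here, none of the measured steps bears on this change: the only step measured so far, from compound 1 to compound 2, concerns configuration alone and was within the scatter, and no pair of compounds differing at this aromatic carbon has been measured. The expectation for compound 3 therefore rests on the value of compound 2 alone, and is worded as an estimate with a wide range: compound 3 is expected to give 250 nM, between 70 nM and 900 nM, which would mean an estimated step of a 1.4-fold higher number from compound 2 to compound 3 (0.15 log units; within the scatter).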

Compound 3, half-maximal effective concentration: 134 nM
Beside the measured number, compound 3's estimate is 1.9-fold (0.27 log units) above it, and the stated range covers the measured number.
By their numbers in this assay, from the lowest: compounds 3, 2 and 1 (each within the scatter of the next, the first and the last beyond it).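

At this aromatic carbon, ortho to a chloro group and two atoms from the ring nitrogen, methyl in place of chloro gives a 1.3-fold lower number from compound 2 to compound 3 (0.12 log units; within the scatter) in this assay. This is the only pair shown that differs at this position, and it shows that, with the configuration of compound 2 kept, the chloro group here can be exchanged for methyl without a change that stands out from the scatter, so in this pair the chlorine at this place is not needed to keep the number in the same range. Nothing in the evidence at hand bears on this exchange, so the result stands as an observation without an explanation.

Chloro and methyl each bring a single heavy atom and no hydrogen-bond donors or acceptors, so the compounds shown leave open how a methoxy group, an amine, a nitrile or a longer chain such as propyl would fare at this carbon. Also open, as far as these compounds go, is whether the same exchange would read alike in the mirror-image series of compound 1, or at the remaining chloro group on the ring.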